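A few compounds are considered here, and "the series" means these few. Any claim that something is new, unique, unknown or untested is made for them only; others in the source may bear on it.

Compound 1 `O=C1NC(=O)C2(CSC3=C2C(=O)c2ncccc2C3=O)N1` is the unsubstituted parent of the series. In a functional assay on SF-268 cells (Homo sapiens) for antiproliferative activity, read by MTT assay, with a stated time of 96 h (on this read-out higher numbers stand for weaker inhibition and lower numbers for stronger inhibition), compound 1 gives 3100 nM, the highest of the three numbers in hand, though within the scatter of both others. Within the data shown here, compound 2 `Cc1ccc(N2NC(=O)NC3(CSC4=C3C(=O)c3ncccc3C4=O)C2=O)cc1` gives 2100 nM and compound 3 `O=C1NN(c2ccc(Cl)cc2)C(=O)C2(CSC3=C2C(=O)c2ncccc2C3=O)N1` gives 2000 nM; these two carry an aryl group on a different ring of the shared core, and the only single-point step among them, a 1.1-fold lower number from compound 2 to compound 3 (0.02 log units; within the scatter), shows that swapping the substituent on that aryl ring leaves the number essentially unchanged. Among the measured compounds shown here, no step from compound 1 to compound 2 or compound 3 is defined, but their values sit in the same range as compound 1.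

Compound 4 `CCCCc1ccc(N2C(=O)NC3(CSC4=C3C(=O)c3ncccc3C4=O)C2=O)cc1` differs from compound 1 by 4-butylphenyl in place of hydrogen on an amide-type nitrogen in a ring. For the measured compounds named here, no measured step bears directly on this position; the closest evidence is that the aryl-bearing compounds 2 and 3 show numbers in the scatter band of compound 1, so the step of a 1.2-fold lower number from compound 1 to compound 4 (0.09 log units; within the scatter) is expected to be small or none beyond the scatter. In this assay compound 4 is estimated at 2500 nM, within a range of 1000 nM to 6500 nM.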

Compound 4, half-maximal inhibitory concentration: 400 nM
Compound 4: the middle estimate sits 6.3-fold (0.80 log units) above what was measured; measured number below the stated range.
By their numbers in this assay, from the lowest: compound 4; then compounds 3, 2 and 1 (each within the scatter of the next).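

In this assay, among these compounds, the amide-type nitrogen in the five-membered non-aromatic ring proves sensitive to substitution: 4-butylphenyl in place of hydrogen gives a 7.8-fold lower number from compound 1 to compound 4 (0.89 log units; beyond the scatter) and is the only step from compound 1 in hand at this position. The aryl groups of compound 2 and compound 3 sit on a different ring of the shared core, so they gave no reading of this nitrogen. Nothing measured here accounts for the size of the step.

Open, on these data alone, is whether the step rests on the phenyl ring alone or needs the butyl chain: an unsubstituted phenyl or a longer chain such as hexyl on this nitrogen would separate the two. Also open, as far as these compounds go, is whether an amine or a carboxylic acid at the end of the chain would keep the step.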